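Swapping a Hydroxypropyl Chain for a Dimethoxyphenyl Ring

A few compounds are considered here, and "the series" means these few. Any claim that something is new, unique, unknown or untested is made for them only; others in the source may bear on it.

Of the compounds shown here, two have been measured so far in an assay on isolated protein for binding affinity to thyroid hormone receptor alpha (Homo sapiens); a lower number here means tighter binding, a higher number weaker binding. Compound 1 `C=CCC(c1ccc(O)c(C(C)C)c1)c1c(C)cc(OCC(=O)O)cc1C` gives 430 nM. Compound 2 `Cc1cc(OCC(=O)O)cc(C)c1C(CCCO)c1ccc(O)c(C(C)C)c1` gives 1400 nM, the higher of the two numbers, so compound 2 is the weaker binder of the pair. Among the compounds with values here, the only step recorded between measured compounds is a 3.3-fold higher number from compound 1 to compound 2 (0.51 log units; beyond the scatter), a change in which a short chain carrying a hydroxyl group replaced a vinyl group on the same chain carbon.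

Compound 3 `COc1ccc(C(c2ccc(O)c(C(C)C)c2)c2c(C)cc(OCC(=O)O)cc2C)c(OC)c1` differs from compound 2 by 2,4-dimethoxyphenyl in place of 3-hydroxypropyl on a saturated chain carbon bound to two aromatic carbons. Within the data shown here, no measured step bears directly on this change: the one known step swaps one small chain for another, whereas here a chain carrying a hydrogen-bond donor gives way to a much larger aromatic ring carrying none. The known step does show that binding to this assay responds to what sits on that chain carbon, and it weakened binding when the hydroxyl-bearing chain arrived, so removing that chain could plausibly undo part of the loss. Beyond this, the direction for such a large replacement is uncertain.

Compound 3 is therefore expected to give about 400 nM, with a likely range from 80 nM to 2000 nM. This estimate corresponds to a 3.5-fold lower number from compound 2 to compound 3 (0.54 log units; beyond the scatter).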

Compound 3, dissociation constant: 1400 nM
For compound 3 the middle estimate is 3.5-fold (0.54 log units) below the measured one; measured number inside the range.
By their numbers in this assay, from the lowest: compound 1; then compounds 2 and 3 (each within the scatter of the next).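

In this assay the 2,4-dimethoxyphenyl group, with 10 heavy atoms and 0 hydrogen-bond donors, stands in place of 3-hydroxypropyl, with 4 heavy atoms and 1 hydrogen-bond donor, on the saturated chain carbon bound to two aromatic carbons, and the two compounds read level (no change at the digits printed from compound 2 to compound 3 (within the scatter)). This position therefore accepts a much larger group carrying an aromatic ring with no loss against the hydroxyl-bearing chain, yet the ring does not recover what separates these compounds from the allyl compound (a 3.3-fold higher number from compound 1 to compound 3 (0.51 log units; beyond the scatter)), so compound 1 remains the tightest binder of the three. Nothing available here explains why two such different groups land at the same number.

The compounds shown leave open whether the two methoxy groups matter at all, which a plain phenyl ring on the same carbon would test. They also leave open whether the hydroxyl counts for anything, which a plain propyl chain would test, and whether a chain ending in an amine would fall closer to allyl or to these two groups.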